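Fluoro for Methoxy: Expected Lipophilicity of Compound 4

A few compounds are considered here, and "the series" means these few. Any claim that something is new, unique, unknown or untested is made for them only; others in the source may bear on it.

Measured compounds:
compound 1, `O=S(=O)(c1ccccc1)N1N=C2CCCCC2C1c1ccc(F)cc1`, 5
compound 2, `COc1ccc(C2C3CCCCC3=NN2S(=O)(=O)c2ccccc2)cc1`, 4.6
compound 3, `COc1ccc(C2C3CCCCC3=NN2S(=O)(=O)c2ccc([N+](=O)[O-])cc2)cc1`, 4.5

Of the compounds shown here, three have been measured in a physicochemical assay for lipophilicity, measured as octanol-water partition; on this read-out higher numbers stand for higher lipophilicity and lower numbers for lower lipophilicity. Compound 1 gives 5, compound 2 gives 4.6 and compound 3 gives 4.5. Compound 3 has the lowest of the three numbers, but its gap to compound 2 is within the scatter, so no order between those two is claimed.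

The change from compound 2 to compound 1 is fluoro in place of methoxy on an aromatic carbon. It made a step of a number 0.40 log units higher from compound 2 to compound 1 (beyond the scatter).

Compound 4, `O=[N+]([O-])c1ccc(S(=O)(=O)N2N=C3CCCCC3C2c2ccc(F)cc2)cc1`, has not yet been measured. It differs from compound 3 by fluoro in place of methoxy on an aromatic carbon. The two cores differ in turn by nitro in place of hydrogen on an aromatic carbon, a change that made a step of a number 0.10 log units lower from compound 2 to compound 3 (within the scatter). The place lines of the two changes read the same word for word, so the change from compound 3 to compound 4 is the same change as that from compound 2 to compound 1, set on a core that carries nitro where compound 2 carries hydrogen.

Among the measured compounds shown here, because the only measured example of this change gave a number 0.40 log units higher from compound 2 to compound 1 (beyond the scatter), a step of similar size is expected from compound 3 to compound 4, namely a number 0.40 log units higher from compound 3 to compound 4 (beyond the scatter). In this assay compound 4 is therefore estimated at 4.9, with a range of 4.6 to 5.2 expected to cover most repeat measurements. That expectation rests on a single measured instance of the change, and on the small step from compound 2 to compound 3 suggesting the nitro-bearing core behaves much like the unsubstituted one.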

Compound 4, partition coefficient: 4.9
Compound 4: the middle estimate sits on the measured number at the digits printed, within the range that was stated.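

In this assay, fluoro in place of methoxy gave a number 0.40 log units higher from compound 3 to compound 4 (beyond the scatter) on the core that carries nitro, and the same change gave a number 0.40 log units higher from compound 2 to compound 1 (beyond the scatter) on the core that carries hydrogen, so the step kept its size when carried from the one core to the other. Among the compounds shown here, the nitro-for-hydrogen change, read the other way around on the fluoro-bearing core, gave a number 0.10 log units lower from compound 1 to compound 4 (within the scatter) and on the methoxy-bearing core gave a number 0.10 log units lower from compound 2 to compound 3 (within the scatter), which closes the square of four compounds and claims no order within either pair. This agreement rests on two pairs and one change, so it does not show that the step would hold on any other core, and no measurement at hand speaks to what lies behind the agreement.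

The cores shown differ only by hydrogen or nitro, which leaves open whether the fluoro-for-methoxy step keeps its size where an amine or a carboxylic acid stands in the place of the nitro. From the compounds shown here alone, it also remains open whether a different group entering in place of methoxy, such as chloro or a longer chain, would give steps that agree across these two cores.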